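The source may report more compounds than this note shows. Statements on the series, on what has been measured and on what is new or still open speak of the compounds shown alone.

Compound 1 `CCCCCCCCCCCCCCCCCCNC(=O)[C@H]1CSC(Cc2ccccc2)N1`: 15300 nM
Compound 2 `CCCCCCCCCCCCCCCCCCNC(=O)[C@H]1CSC(c2ccc([N+](=O)[O-])cc2)N1`: 15300 nM
Compound 3 `CCCCCCCCCCCCCCCCCCNC(=O)[C@H]1CSC(c2cc(F)cc(F)c2)N1`, a limit of the assay : > 20000 nM

Of the compounds shown here, three sharing one core have been measured in a functional assay on DU-145 cells (Homo sapiens) for antiproliferative activity, read by sulforhodamine B assay; a higher number here means a weaker inhibitor, a lower number a stronger inhibitor. Compound 1 gives 15300 nM and stands level with compound 2, which gives 15300 nM; the step of no change at the digits printed from compound 1 to compound 2 (within the scatter) lies within the scatter. For compound 3 the assay returned only a limit, (the limit of > 20000 nM in this assay, at which 1 of the 3 values shown sits). The steps of an at least 1.3-fold higher number from compound 1 to compound 3 (0.11 log units; that floor lies within the scatter) and an at least 1.3-fold higher number from compound 2 to compound 3 (0.11 log units; that floor lies within the scatter) are floors that lie within the scatter, so no difference beyond the scatter has been seen among the three.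

Compound 4 `CCCCCCCCCCCCCCCCCCNC(=O)[C@H]1CSC(c2ccc(C)cc2)N1` differs from compound 1 in one place: 4-methylphenyl in place of benzyl on a saturated ring carbon. The measured steps that bear on this change are the two in which an aromatic ring directly attached to that saturated ring carbon replaces benzyl. Neither moved the number beyond the scatter, and one of them ended at a limit. On that basis one expects from the change to compound 4 no step beyond the scatter in this assay, with a leaning toward a slightly higher number and a real chance that only a limit is returned.

Compound 4 is therefore expected to give 18000 nM, in the range 9000 nM to 40000 nM. The step of a 1.2-fold higher number from compound 1 to compound 4 (0.07 log units; within the scatter) is expected to stay within the scatter.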

Compound 4, half-maximal inhibitory concentration: 10500 nM
The estimate for compound 4 lay 1.7-fold (0.23 log units) above the measured number, and the stated range covers the measured number.
By their numbers in this assay, from the lowest: compounds 4, 1 and 2 (each within the scatter of the next). At a limit, above all of these: compound 3.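

In this assay, 4-methylphenyl on the saturated ring carbon gives a 1.5-fold lower number from compound 1 to compound 4 (0.16 log units; within the scatter), and methyl in place of nitro on the aromatic carbon gives a 1.5-fold lower number from compound 2 to compound 4 (0.16 log units; within the scatter). This adds a third aromatic ring attached directly to that carbon, and a first change made on the aromatic ring itself, and neither of these steps leaves the scatter, while an at least 1.9-fold lower number from compound 3 to compound 4 (0.27 log units; that floor lies within the scatter) is only a floor. That floor rests on compound 3, whose reading is a limit of the assay and not a number: the limit of > 20000 nM in this assay, at which 1 of the 4 values shown sits.

For the compounds shown here, no step at this position has yet gone beyond the scatter, so it remains unknown whether any group placed here can move the number in this assay by more than that, for instance an amine or a carboxylic acid on the aromatic ring, or a pyridine ring in place of the benzene ring. Also open, going by these compounds, is how much of the number depends on the long chain shared by all four compounds, which a shorter chain or a longer chain on the amide nitrogen would test.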